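Cyano in Place of Chloro: Expecting Compound 4

A few compounds are considered here, and "the series" means these few. Any claim that something is new, unique, unknown or untested is made for them only; others in the source may bear on it.

- Compound 1 `CNc1nc(NC)nc(NC2(C#N)CCCCC2)n1`: in an in vitro assay on Sf21 cells for inhibition of high affinity 3',5'-cyclic-AMP phosphodiesterase 7A (Homo sapiens) (a lower number here means a stronger inhibitor, a higher number a weaker inhibitor), compound 1 gives > 1000 nM, which is a limit.
- Compound 2 `CNc1nc(NC2(C#N)CCCCC2)nc(N(C)C)n1`: in this assay compound 2 gives > 5000 nM, also a limit.
- Compound 3 `CNc1nc(Cl)nc(NC2(C#N)CCCCC2)n1`: in this assay compound 3 gives 1070 nM.

Among the compounds with values here, compound 3 therefore holds the only real number; the other two values are limits. Compound 4 `CNc1nc(C#N)nc(NC2(C#N)CCCCC2)n1` differs from compound 3 by cyano in place of chloro on an aromatic carbon. The steps from compound 1 cannot be read: a step that the two limits leave unreadable from compound 1 to compound 2 and a step that the limit leaves unreadable from compound 1 to compound 3. Within the data shown here, the one readable step, an at least 4.6-fold lower number from compound 2 to compound 3 (0.66 log units; beyond the scatter), concerns the same aromatic carbon, but no measured step replaces chloro with cyano, so in this assay no step beyond the scatter is expected; the expected step is a 1.1-fold lower number from compound 3 to compound 4 (0.03 log units; within the scatter). Compound 4 is estimated at 1000 nM, between 300 nM and 3500 nM.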

Compound 4, half-maximal inhibitory concentration: > 1000 nM
Compound 4: a limit, no number; the forecaster's own chance of this, stated with the estimate: 25%; the middle value lies on the limit itself.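

In this assay, within the data shown here, compound 4 gives > 1000 nM, which is a limit and not a number, so no step linking it to compound 1, compound 2 or compound 3 can be read. From the compounds shown here alone, whether cyano in place of chloro changes the inhibition of compound 3 stays open.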